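Cytotoxicity working notes: compounds 1 to 4

The compounds below may be only part of what the source reports. "The series", "measured", "known", "first", "only" and "open" are said of these compounds alone.

In an ADME assay on Ava5 cells (Homo sapiens) for cytotoxicity (on this read-out higher numbers stand for lower toxicity in this test and lower numbers for higher toxicity in this test), compound 1 `NC(=S)Nc1cccc(OCCCc2ccccc2)c1` gives > 50000 nM, a limit of the assay.
In this assay compound 2 `NC(=S)Nc1cccc(OCCCCCOc2ccc(C(=O)O)cc2)c1` gives > 50000 nM, a limit of the assay.
In this assay compound 3 `NC(=S)Nc1cccc(OCCCCCOc2ccc(-c3ccccc3)cc2)c1` gives > 50000 nM, a limit of the assay.

Compound 3 stands at the limit, as do the other two values, since (the limit of > 50000 nM in this assay, at which 3 of the 3 values shown sit). Within the data shown here, the one step between measured compounds, a step that the two limits leave unreadable from compound 2 to compound 3, is therefore not readable. Compound 4 `NC(=S)Nc1cccc(OCCCCCOc2ccc(-c3ccco3)cc2)c1` differs from compound 3 by furan-2-yl in place of phenyl on an aromatic carbon. No measured step can be read, so the expectation for compound 4 rests on the limit alone: a step of a number no higher from compound 3 to compound 4 (the limit leaves the size open) is expected, none beyond the scatter. Compound 4 is estimated at 50000 nM, between 25000 nM and 100000 nM, most likely again a limit.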

Compound 4, half-maximal cytotoxic concentration: 11000 nM
Compound 4: the middle estimate sits 4.5-fold (0.66 log units) above what was measured, and the stated range ends above it.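

Among these compounds, the aromatic carbon para to a large group can move the read-out in this assay, which the earlier compounds did not show: furan-2-yl in place of phenyl gives an at least 4.5-fold lower number from compound 3 to compound 4 (0.65 log units; beyond the scatter), meaning higher toxicity in this test. Furan-2-yl in place of carboxy gives an at least 4.5-fold lower number from compound 2 to compound 4 (0.65 log units; beyond the scatter), so compound 4 stands apart from both of these compounds. Each step starts from a limit, so its full size stays open: the limit of > 50000 nM in this assay, at which 3 of the 4 values shown sit.

As far as these compounds go, whether the change follows from the furan-2-yl group alone or from five-membered aromatic rings more widely stays open, and a thiophene or a pyridine on this carbon would bear on that. From the compounds shown here alone, how an amine at this place or a longer chain would read also stays open.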